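Aryl amide exchange from compound 2 to compound 3

A few compounds are considered here, and "the series" means these few. Any claim that something is new, unique, unknown or untested is made for them only; others in the source may bear on it.

In a functional assay on K562 cells (Homo sapiens) for inhibition, read by MTT assay, with a stated time of 48 h (a lower number here means a stronger inhibitor, a higher number a weaker inhibitor), compound 2 (`Nc1nc2ccc(-c3cn([C@@H]4CN[C@H](C(=O)Nc5ccc(Cl)c(C(F)(F)F)c5)C4)nn3)nc2s1`) gives 26200 nM and compound 1 (`CC(C)(C)OC(=O)N1C[C@@H](n2cc(-c3ccc4nc(N)sc4n3)nn2)C[C@H]1C(=O)Nc1ccc(Br)cc1`) gives 29200 nM with the two values within the scatter of each other. Compound 3 (`Nc1nc2ccc(-c3cn([C@@H]4CN[C@H](C(=O)Nc5ccc(Br)cc5)C4)nn3)nc2s1`) carries 4-bromophenyl in place of 4-chloro-3-(trifluoromethyl)phenyl on an amide-type nitrogen. Going by the values given here, the 4-bromophenyl group also stands in compound 1, but no measured pair isolates this exchange. No step beyond the scatter is expected in this assay and no direction can be called. The expected step is a 1.1-fold higher number from compound 2 to compound 3 (0.03 log units; within the scatter) on this estimate. Compound 3 is estimated at 28000 nM (13000 nM to 55000 nM).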

Compound 3, half-maximal inhibitory concentration: 24400 nM
For compound 3 the middle estimate is 1.1-fold (0.06 log units) above the measured one; measured number inside the range.
By their numbers in this assay, from the lowest: compounds 3, 2 and 1 (each within the scatter of the next).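

In this assay, going by these compounds alone, replacing 4-chloro-3-(trifluoromethyl)phenyl with 4-bromophenyl on the amide-type nitrogen gives a 1.1-fold lower number from compound 2 to compound 3 (0.03 log units; within the scatter), so the first isolated exchange at this position does not separate these two aryl groups. Hydrogen in place of tert-butoxycarbonyl on the amine nitrogen in the ring gives a 1.2-fold lower number from compound 1 to compound 3 (0.08 log units; within the scatter), so that position is not separated by this change either. No evidence bears on why these numbers stay together.

As far as these compounds go, it remains open whether an aryl group carrying an amine or a carboxylic acid on the amide-type nitrogen would move the number beyond the scatter. The same question stands for an acetyl group on the amine nitrogen in the ring.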